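This account rests on a few compounds, and the source may have more. Where it says the series, first, only, none or still open, it means among the compounds named here.

Series notes. Compound 1 `CC(=O)OC[C@H]1O[C@H](OC[C@@H](Cn2cc(CN(c3nc(-c4cccc([N+](=O)[O-])c4)no3)C3CCCCC3)nn2)OC(C)=O)C=C[C@@H]1OC(C)=O` and compound 2 `CC(=O)OC[C@H]1O[C@H](OC[C@@H](Cn2cc(CN(c3nc(-c4ccc(Br)cc4)no3)C3CCCCC3)nn2)OC(C)=O)C=C[C@@H]1OC(C)=O` share one core and differ only in the substituted phenyl group. In an ADME assay on RAW264.7 cells (Mus musculus) for cytotoxicity, read by MTT assay, with a stated time of 48 h (on this read-out higher numbers stand for lower toxicity in this test and lower numbers for higher toxicity in this test), compound 1 gives 100 ug/mL and compound 2 gives 39.1 ug/mL. The move a 2.6-fold lower number from compound 1 to compound 2 (0.41 log units; beyond the scatter) was modest, 4-bromophenyl in place of 3-nitrophenyl. On these two numbers compound 2 stands lowest, with compound 1 the nearest and higher by that step. Compound 3 `CC(=O)OC[C@H]1O[C@H](OC[C@@H](Cn2cc(CN(c3nc(-c4ccc(C(F)(F)F)cc4)no3)C3CCCCC3)nn2)OC(C)=O)C=C[C@@H]1OC(C)=O` carries trifluoromethyl in place of bromo on an aromatic carbon. Within the data shown here, no measured step bears directly on this exchange; the single known step, a 2.6-fold lower number from compound 1 to compound 2 (0.41 log units; beyond the scatter), changed both the group and its place on the phenyl and was itself modest. The leaving and entering groups sit on the same aromatic carbon, and neither brings a donor or acceptor, so in this assay no step beyond the scatter is expected for compound 3, a 1.0-fold higher number from compound 2 to compound 3 (0.01 log units; within the scatter). Compound 3 is estimated at 40 ug/mL, with an expected range from 15 ug/mL to 100 ug/mL.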

Compound 3, half-maximal cytotoxic concentration: 64.1 ug/mL
For compound 3 the middle estimate is 1.6-fold (0.20 log units) below the measured one, and the stated range covers the measured number.
By their numbers in this assay, from the lowest: compounds 2, 3 and 1 (each within the scatter of the next, the first and the last beyond it).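

In this assay, the exchange of bromo for trifluoromethyl on the aromatic carbon para to a large group keeps the place on the phenyl fixed and gives a 1.6-fold higher number from compound 2 to compound 3 (0.21 log units; within the scatter), while 4-(trifluoromethyl)phenyl in place of 3-nitrophenyl gives a 1.6-fold lower number from compound 1 to compound 3 (0.19 log units; within the scatter). Compound 3 therefore cannot be told apart from either of the other two compounds, although those two remain separated by a 2.6-fold lower number from compound 1 to compound 2 (0.41 log units; beyond the scatter). The 4-bromophenyl and 4-(trifluoromethyl)phenyl groups are thus not distinguished at this position in this test.

No supporting measurement is available to explain these numbers. Going by these compounds, whether an amine or a carboxylic acid on the same aromatic carbon would fall within this span remains open, as does the outcome for bromo or trifluoromethyl at the place of the nitro group in compound 1.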